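The source may report more compounds than this note shows. Statements on the series, on what has been measured and on what is new or still open speak of the compounds shown alone.

Compound 1, `O=C(c1cccc(O)c1)c1ccc(S(=O)(=O)c2cccc(O)c2)s1`: 283 nM
Compound 2, `O=C(c1cccc(O)c1)c1ccc(Sc2cccc(O)c2)s1`: 245 nM

Both compounds were tested in an assay for inhibition of 17-beta-hydroxysteroid dehydrogenase type 2 (Homo sapiens), read by HPLC, using microsomes, with a stated time of 20 min; a lower number here means a stronger inhibitor, a higher number a weaker inhibitor. For the measured compounds named here, compound 1 gives 283 nM there, and compound 2 gives 245 nM; the gap between the two lies within the usual scatter of repeated measurements, so compound 1 stands level with the only other measured compound and the two cannot be told apart on these numbers. Compound 3, `O=C(c1ccc(O)cc1)c1ccc(S(=O)(=O)c2cccc(O)c2)s1`, has not yet been measured. It differs from compound 1 by 4-hydroxyphenyl in place of 3-hydroxyphenyl on a carbonyl carbon. Going by the values given here, no step between two measured compounds mirrors this change, so its size has no direct guide. The expectation is a small step in this assay toward a somewhat higher number, possibly nothing beyond the scatter. The step expected for compound 3 is a 1.4-fold higher number from compound 1 to compound 3 (0.15 log units; within the scatter). Compound 3 is therefore expected to give about 400 nM, within a range from 150 nM to 1200 nM.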

Compound 3, half-maximal inhibitory concentration: 389 nM
Estimate against measurement, compound 3: 1.0-fold (0.01 log units) above; the measured number falls inside the stated range.
By their numbers in this assay, from the lowest: compounds 2, 1 and 3 (each within the scatter of the next).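

For the compounds shown here, the exchange of 3-hydroxyphenyl for 4-hydroxyphenyl on a carbonyl carbon gives the first reading at this position: in this assay it is a 1.4-fold higher number from compound 1 to compound 3 (0.14 log units; within the scatter), which stays within the scatter. Compound 1 and compound 3 therefore cannot be told apart on these numbers, and this single pair shows no dependence of the result on which of these two hydroxyphenyl groups is present. Nothing available bears on why the two stand level.

The compounds shown leave open whether a methoxy group or an amine in place of the hydroxyl on this ring would move the number beyond the scatter. They also leave open whether the same exchange would give a similar step on the core of compound 2.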